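Valine amide with trifluoromethoxy: an expected seizure dose

The compounds below may be only part of what the source reports. "The series", "measured", "known", "first", "only" and "open" are said of these compounds alone.

Measured compounds:
Compound 1 `CC(C)(C)[C@@H](N)C(=O)NCc1ccc(OC(F)(F)F)cc1` in a functional assay on the whole organism (strain albino Sprague-Dawley) with Rattus norvegicus as the target, in the maximal electroshock model (a lower number here means that less compound is needed, a higher number that more compound is needed for the effect), gives 23 mg/kg.
Compound 2 `CC(C)[C@@H](N)C(=O)NCc1ccc(Cl)cc1` in this assay gives "not determined" (no result reported), that is, no result is reported for it.

Compound 2 therefore stands nowhere on the numbers: no dose for half-maximal effect exists for it, and nothing can be said about where it would fall in relation to compound 1. The account follows the change from compound 2 to compound 3 `CC(C)[C@@H](N)C(=O)NCc1ccc(OC(F)(F)F)cc1`, which is trifluoromethoxy in place of chloro on an aromatic carbon. Going by the values given here, since compound 2 carries no value, no step can be computed, and the size of the step in this assay cannot be read from the two compounds themselves; any expectation has to rest elsewhere.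

What remains is compound 1, which shares the trifluoromethoxy-bearing part with compound 3. In this assay compound 1 gives 23 mg/kg. The expectation is that compound 3 sits in the same region, with a broad range to cover the unknown contribution of the amino acid side chain. Compound 3 is expected to give 30 mg/kg in this assay, with a range from 10 mg/kg to 90 mg/kg.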

Compound 3, dose for half-maximal effect: 18 mg/kg
Beside the measured number, compound 3's estimate is 1.7-fold (0.22 log units) above it; the measured number falls inside the stated range.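

Going by these compounds alone, with 18 mg/kg in this assay, compound 3 gives the trifluoromethoxy series a second number and shows what the earlier compounds could not: how this read-out responds to a change in the amino acid side chain while the trifluoromethoxy group stays in place. Hydrogen in place of methyl on a saturated chain carbon bound to three saturated chain carbons gives a 1.3-fold lower number from compound 1 to compound 3 (0.11 log units; within the scatter), so this single change in the side chain leaves no difference that can be separated from the usual variation between repeated measurements. No measured evidence is available to explain this result or to connect it to any property of either compound.

On these data alone, the step from chloro to trifluoromethoxy on the aromatic carbon still cannot be read, as compound 2 has no value in this assay, so the contribution of that exchange remains unknown. The compounds shown also leave open whether a methoxy group or a nitrile at that aromatic carbon, or a longer chain in the amino acid side chain, would keep the dose in the same region.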